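The compounds below may be only part of what the source reports. "The series", "measured", "known", "first", "only" and "open" are said of these compounds alone.

Measured in an ADME assay on microsomes from liver (Mus musculus) for metabolic stability, with a stated time of 10 min; a lower number here means that less of the compound is left, a higher number that more of the compound is left:

- compound 1 `C[C@]1(C(=O)N2CC[C@](c3ccc(C(F)(C(F)(F)F)C(F)(F)F)cc3)(S(=O)(=O)c3ccc(F)cc3)C2)CC[C@H](C(=O)O)CC1`: 95%
- compound 2 `C[C@]1(C(=O)N2CC[C@](c3ccc(C(F)(C(F)(F)F)C(F)(F)F)cc3)(S(=O)(=O)c3ccc(F)cc3)C2)CC[C@@H](C(=O)O)CC1`: 100%
- compound 3 `O=C([C@H]1CC[C@H](c2nnn[nH]2)CC1)N1CC[C@](c2ccc(C(F)(C(F)(F)F)C(F)(F)F)cc2)(S(=O)(=O)c2ccc(F)cc2)C1`: 73%

In this assay, compound 3 stands lowest of the three at 73%, and its steps to both others lie beyond the scatter. The next compound to be read against it is compound 4 `NC(=O)[C@H]1CC[C@H](C(=O)N2CC[C@](c3ccc(C(F)(C(F)(F)F)C(F)(F)F)cc3)(S(=O)(=O)c3ccc(F)cc3)C2)CC1`, which carries carbamoyl in place of 1H-tetrazol-5-yl on a saturated ring carbon.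

Going by the values given here, two measured steps bear on this change, since both swap 4-carboxy-1-methylcyclohexyl for 4-(1H-tetrazol-5-yl)cyclohexyl: a number 22 percentage points lower from compound 1 to compound 3 (beyond the scatter) and a number 27 percentage points lower from compound 2 to compound 3 (beyond the scatter). Both are modest. They give only a rough size for a change on this part of the molecule, since neither involves carbamoyl and neither shows which way a move away from 1H-tetrazol-5-yl would go. The remaining step, a number 5 percentage points higher from compound 1 to compound 2 (within the scatter), adds little here, as it concerns (the fact that compounds 1 and 2 differ only in the configuration as drawn).

With a direction unsupported by these data, no shift beyond the scatter is expected, though a move as large as those modest steps remains possible. The expected step is a number 3 percentage points lower from compound 3 to compound 4 (within the scatter). Compound 4 is estimated at 70%, with an expected range from 48% to 90%.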

Compound 4, percent of the compound remaining: 100%
For compound 4 the middle estimate is 30 percentage points below the measured one, and the stated range ends below it.
By their numbers in this assay, from the lowest: compound 3; then compounds 1, 2 and 4 (each within the scatter of the next).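

In this assay, the change at this saturated ring carbon now has a direction: the step is a number 27 percentage points higher from compound 3 to compound 4 (beyond the scatter) when carbamoyl replaces 1H-tetrazol-5-yl, with the rest of the molecule unchanged. The new value also places the amide level with both compounds that carry 4-carboxy-1-methylcyclohexyl, the steps being no change at the digits printed from compound 2 to compound 4 (within the scatter) and a number 5 percentage points higher from compound 1 to compound 4 (within the scatter), so among these four compounds only the 1H-tetrazol-5-yl compound stands apart, although these last two steps change the ring's methyl group as well as the group on the ring. Nothing in the information at hand gives a reason for the step from the tetrazole to the amide.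

As far as these compounds go, it stays open whether the higher number belongs to carbamoyl in particular or would follow from other replacements for 1H-tetrazol-5-yl at this place, such as an amine or a nitrile. A carboxylic acid on the same ring without the methyl group would also separate the effect of the acid from that of the methyl group, which the compounds shown change together.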